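The compounds below may be only part of what the source reports. "The series", "measured", "known", "first", "only" and "open" are said of these compounds alone.

Three nucleoside-like compounds were tested in an ADME assay on L1210/0 cells (Mus musculus) for cytotoxicity, with a stated time of 48 h; on this read-out lower numbers stand for stronger inhibition and higher numbers for weaker inhibition. Compound 1 `O=c1[nH]cnc2c1nnn2C1C[C@H](CO)[C@@H](CO)[C@@H]1CO` reaches only the assay limit of > 200000 nM. Compound 2 `CC1(C)C(CO)CC1Cn1nnc2c(Cl)nc(N)nc21` likewise gives only the limit of > 200000 nM. Compound 3 `O=c1[nH]c(=O)n([C@H]2C[C@H](O)[C@@H](CO)O2)cc1C#CCO` also stops at the limit of > 200000 nM. Compound 3 therefore stands where every value shown stands, which is the limit of > 200000 nM in this assay, at which 3 of the 3 values shown sit, with no number separating it from compounds 1 and 2.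

Compound 4 `CCCc1cn([C@H]2C[C@H](O)[C@@H](CO)O2)c(=O)[nH]c1=O` differs from compound 3 by propyl in place of 3-hydroxyprop-1-yn-1-yl on an aromatic carbon. Within the data shown here, no measured step with this change exists here, so in this assay no shift beyond the usual scatter is expected, and compound 4 is expected to remain near the limit with an estimated 250000 nM between 60000 nM and 1000000 nM, an expected change of a step that the limit leaves unreadable from compound 3 to compound 4.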

Compound 4, half-maximal inhibitory concentration: > 200000 nM
Compound 4: no number, only a limit; the forecaster's own chance of this, stated with the estimate: 80%; the middle value lies beyond the limit too.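

Compound 3 and compound 4 both give only a limit in this assay and no step can be read between them. The compounds shown leave open whether propyl in place of 3-hydroxyprop-1-yn-1-yl changes cytotoxicity at all.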